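The source may report more compounds than this note shows. Statements on the series, on what has been measured and on what is new or still open speak of the compounds shown alone.

Measured compounds in the series:

Compound 1, `C=C1C(=O)[C@]23C[C@@]1(O)CC[C@H]2c1ccc(OS(=O)(=O)c2ccc(C)cc2)c(C)c1[C@@H]3Cn1cc(-c2ccccn2)nn1`, gives 2830 nM.
Compound 2, `C=C1C(=O)[C@]23C[C@@]1(O)CC[C@H]2c1ccc(OS(=O)(=O)c2ccc(C)cc2)c(C)c1[C@@H]3Cn1cc(-c2ccc(F)cc2)nn1`, gives 4280 nM.
Compound 3, `C=C1C[C@]23C[C@@]1(O)CC[C@H]2c1cc(Br)c(O)c(C)c1[C@@H]3Cn1cc(-c2ccc(F)cc2)nn1`, is reported at > 20000 nM, which is a limit of the assay and not a number.

All three values come from a functional assay on SMMC-7721 cells (Homo sapiens) for cytotoxicity, read by MTT assay, with a stated time of 4 days; on this read-out higher numbers stand for weaker inhibition and lower numbers for stronger inhibition. Compound 2 and compound 1 differ in one place, (pyridin-2-yl in place of 4-fluorophenyl on an aromatic carbon), and the step is a 1.5-fold lower number from compound 2 to compound 1 (0.18 log units; within the scatter). On this evidence the exchange of the two aryl groups on the triazole leaves the read-out essentially unchanged.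

Compound 3 carries a different core; how the core of compound 3 differs from the core of compound 2 is not broken down here. For compound 3 the assay returned a limit, (the limit of > 20000 nM in this assay, at which 1 of the 3 values shown sits), so its position relative to compound 1 and compound 2 is known only as lying at that end of the range.

Compound 4, `C=C1C[C@]23C[C@@]1(O)CC[C@H]2c1cc(Br)c(O)c(C)c1[C@@H]3Cn1cc(-c2ccccn2)nn1`, has not been measured. It differs from compound 3 by pyridin-2-yl in place of 4-fluorophenyl on an aromatic carbon, the same change, made at the same place, as that from compound 2 to compound 1. Given that this change produced a step within the scatter, the expected step from compound 3 to compound 4 in this assay is a number no higher from compound 3 to compound 4 (the limit leaves the size open). Because compound 3 sits at the limit of > 20000 nM in this assay, at which 1 of the 3 values shown sits, the most likely outcome for compound 4 is again a limit rather than a number. Compound 4 is accordingly estimated at 20000 nM, with a range from 8000 nM to 60000 nM.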

Compound 4, half-maximal inhibitory concentration: > 20000 nM
Compound 4: no number, only a limit; the forecaster's own chance of this, stated with the estimate: 75%; the middle value sits exactly at the limit.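

No step between compound 3 and compound 4 can be read in this assay, as each of the two compounds is reported only as a limit of the assay and not as a number: the limit of > 20000 nM in this assay, at which 2 of the 4 values shown sit.

The compounds shown leave open whether pyridin-2-yl in place of 4-fluorophenyl changes the read-out at all on the core shared by compound 3 and compound 4.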